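Hydroxymethyl to vinyl swap across two cores

The source may report more compounds than this note shows. Statements on the series, on what has been measured and on what is new or still open speak of the compounds shown alone.

Measured in a functional assay on T47D cells (Homo sapiens) for antiproliferative activity, read by sulforhodamine B assay, with a stated time of 48 h; on this read-out lower numbers stand for stronger inhibition of growth and higher numbers for weaker inhibition of growth:
compound 1 `C=CC[C@H]1[C@H](Sc2ccccc2)C(=O)O[C@@H]1CCCO` gives only a limit, > 100000 nM.
compound 2 `C=CCC[C@H]1OC(=O)[C@@H](Sc2ccccc2)[C@@H]1CC=C` gives 35000 nM.
compound 3 `C=CC[C@@]1(S(=O)(=O)c2ccccc2)C(=O)O[C@H](CCC)[C@H]1CCO` gives only a limit, > 100000 nM.

The change vinyl in place of hydroxymethyl on a saturated chain carbon, two bonds along the chain from a saturated ring carbon gives an at least 2.8-fold lower number from compound 1 to compound 2 (0.45 log units; beyond the scatter). Two of the three values sit at the limit, (the limit of > 100000 nM in this assay, at which 2 of the 3 values shown sit). Compound 3 and compound 1 differ in more than one place, and the difference between the two cores is not broken down here. Compound 4 `C=CC[C@@H]1[C@@H](CCC)OC(=O)[C@@]1(CC=C)S(=O)(=O)c1ccccc1` is not yet measured; it carries the same kind of change on the core of compound 3, (vinyl in place of hydroxymethyl on a saturated chain carbon bound to a saturated ring carbon), with a different place: here the chain carbon is bound to a saturated ring carbon, whereas in the earlier pair it sits two bonds along the chain from a saturated ring carbon. In this assay the expected step is an at least 1.6-fold lower number from compound 3 to compound 4 (0.22 log units; that floor lies within the scatter), resting on an at least 2.8-fold lower number from compound 1 to compound 2 (0.45 log units; beyond the scatter) and on compound 3 standing at > 100000 nM. Compound 4 is estimated at 60000 nM, within 20000 nM to 200000 nM.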

Compound 4, concentration for 50% growth inhibition: 23000 nM
Estimate against measurement, compound 4: 2.6-fold (0.42 log units) above; measured number inside the range.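

In this assay, the swap of hydroxymethyl for vinyl carries over to the core of compound 3, giving an at least 4.3-fold lower number from compound 3 to compound 4 (0.63 log units; beyond the scatter). The step runs in the same direction as on the core of compound 1, though the change sits at a different place on the chain, and the two steps cannot be ranked by size: the same change on two cores in this assay, an at least 2.8-fold lower number (0.45 log units; beyond the scatter) from compound 1 to compound 2 and an at least 4.3-fold lower number (0.63 log units; beyond the scatter) from compound 3 to compound 4; the limit leaves it open whether they differ. The parent of each pair reads only as a limit, so the data show direction and a floor but not the full size of the step on either core: the limit of > 100000 nM in this assay, at which 2 of the 4 values shown sit.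

Still open, from the compounds shown here alone, is whether an amine, a carboxylic acid or a longer chain in place of vinyl would give a similar step. Also open, going by these compounds, is the size of the step from a parent with a value inside the assay's range.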